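This account rests on a few compounds, and the source may have more. Where it says the series, first, only, none or still open, it means among the compounds named here.

Compound 3 `CSc1nc(NCc2ccccc2)c2ccccc2n1` is the only one of the three measured compounds that gives a number in a functional assay on HTB-54 cells (Homo sapiens) for cytotoxicity, read by MTT assay, with a stated time of 72 h (a lower number here means a stronger inhibitor of growth, a higher number a weaker inhibitor of growth), where compound 3 gives 82300 nM. Compound 2 `C[Se]c1nc(NCc2ccccc2)c2ccccc2n1` reaches only a limit of that assay; in this assay compound 2 gives > 100000 nM. Compound 1 `CSc1ccc(CNc2nc([SeH])nc3ccccc23)cc1` likewise sits at a limit, and in this assay compound 1 gives > 100000 nM. Among the compounds with values here, the single measured step, an at least 1.2-fold lower number from compound 2 to compound 3 (0.08 log units; that floor lies within the scatter), exchanges a methylselanyl group for a methylsulfanyl group on the core and stays within the scatter, its size being known only as a floor set by the limit of > 100000 nM in this assay, at which 2 of the 3 values shown sit. Compound 4 `CSc1ccc(CNc2nc(SC)nc3ccccc23)cc1` arises from compound 3 by methylsulfanyl in place of hydrogen on an aromatic carbon. Within the data shown here, no measured step covers this change; compound 1 carries the same methylsulfanyl group on the benzyl ring but differs from compound 4 at the core, and compound 1 shows only a limit. With all values sitting at or near the limit, the step of a 1.0-fold lower number from compound 3 to compound 4 (0.01 log units; within the scatter) is expected to lie within the scatter. Compound 4 is therefore estimated at 80000 nM, between 30000 nM and 200000 nM, with a fair chance that only a limit is reported.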

Compound 4, concentration for total growth inhibition: 44500 nM
Estimate against measurement, compound 4: 1.8-fold (0.25 log units) above; the range from low to high includes it.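

With numbers now on both sides, methylsulfanyl in place of hydrogen on an aromatic carbon, para to a large group, can be read in this assay: a 1.8-fold lower number from compound 3 to compound 4 (0.27 log units; within the scatter), so at this position the group brings no change beyond the scatter. Within the data shown here, the core gives the first step beyond the scatter, with a methylsulfanyl group in place of the selenium atom of compound 1: an at least 2.2-fold lower number from compound 1 to compound 4 (0.35 log units; beyond the scatter). That step is known only as a floor: the limit of > 100000 nM in this assay, at which 2 of the 4 values shown sit.

On these data alone, whether an amine, a carboxylic acid or a longer chain at this same aromatic carbon would move the number beyond the scatter stays open. Also open, as far as these compounds go, is how an amine or a methoxy group in place of the methylsulfanyl group on the core would compare.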